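The source may report more compounds than this note shows. Statements on the series, on what has been measured and on what is new or still open speak of the compounds shown alone.

Three compounds sharing one core, and differing in a single group, have been measured in an ADME assay on U2OS cells (Homo sapiens) for cytotoxicity; a lower number here means that less compound is tolerated, a higher number that more compound is tolerated. Compound 1 `CC(C)(C)c1ccc(C(=O)N/N=C/c2ccc([N+](=O)[O-])o2)cc1`, which carries tert-butyl, reaches only a limit of the assay, > 200000 nM. Compound 2 `CCCCOc1ccc(C(=O)N/N=C/c2ccc([N+](=O)[O-])o2)cc1`, which carries butoxy, gives 46600 nM. Compound 3 `N#Cc1ccc(C(=O)N/N=C/c2ccc([N+](=O)[O-])o2)cc1`, which carries cyano, gives 21400 nM, the lowest number among the three, with compound 2 its nearest neighbour.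

Compound 4 `CCCCCCc1ccc(C(=O)N/N=C/c2ccc([N+](=O)[O-])o2)cc1` has hexyl in place of cyano on an aromatic carbon. Among the compounds with values here, no hexyl compound has been measured, so the closest guides are the steps that involve cyano. Cyano in place of tert-butyl gave an at least 9.3-fold lower number from compound 1 to compound 3 (0.97 log units; beyond the scatter), and cyano in place of butoxy gave a 2.2-fold lower number from compound 2 to compound 3 (0.34 log units; beyond the scatter). Butoxy in place of tert-butyl gave an at least 4.2-fold lower number from compound 1 to compound 2 (0.63 log units; beyond the scatter). Removing cyano is therefore expected to raise the number, and the expected change is a 3.3-fold higher number from compound 3 to compound 4 (0.51 log units; beyond the scatter). For compound 4 the estimated value is 70000 nM, with an expected range of 25000 nM to 200000 nM.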

Compound 4, half-maximal cytotoxic concentration: > 200000 nM
Compound 4: a limit, no number; the forecaster's own chance of this, stated with the estimate: 20%; middle value at least 2.8-fold (0.45 log units) from the limit.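

In this assay, hexyl on this aromatic carbon gives an at least 9.3-fold higher number from compound 3 to compound 4 (0.97 log units; beyond the scatter), and it gives an at least 4.2-fold higher number from compound 2 to compound 4 (0.63 log units; beyond the scatter). A long unbranched chain can therefore sit here with a result as high as the branched tert-butyl of compound 1, so chain length alone does not bring the number down, and butoxy in compound 2 differs from hexyl in more than its length. Compound 4 gives a limit of the assay rather than a number, as does compound 1, so the step between them cannot be read: the limit of > 200000 nM in this assay, at which 2 of the 4 values shown sit.

From the compounds shown here alone, how far compound 4 and compound 1 lie beyond that limit remains unknown. A plain butyl chain would show whether the oxygen of butoxy matters, and an amine or a carboxylic acid at this place would test whether the low number of compound 3 extends beyond cyano.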